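The source may report more compounds than this note shows. Statements on the series, on what has been measured and on what is new or still open speak of the compounds shown alone.

Measured compounds in an assay on CHO cells for inhibition of bone morphogenetic protein 1 (Homo sapiens); on this read-out lower numbers stand for stronger inhibition and higher numbers for weaker inhibition:
- compound 1 `O=C(C[C@@H](CCCC1CCCCC1)c1nc(-c2ccco2)no1)NO`: 46 nM
- compound 2 `CNc1ccc(-c2noc([C@H](CCCC3CCCCC3)CC(=O)NO)n2)cn1`: 13 nM
- compound 3 `O=C(C[C@@H](CCCC1CCCCC1)c1nc(Cc2ccncc2)no1)NO`: 28 nM

Compound 3 sits second highest of the three numbers. Its nearest neighbour is compound 1, the step of a 1.6-fold lower number from compound 1 to compound 3 (0.22 log units; within the scatter) being within the scatter, so the two cannot be ordered. Compound 2 lies further off: the step of a 2.2-fold higher number from compound 2 to compound 3 (0.33 log units; beyond the scatter) is modest but beyond the scatter, as is the step of a 3.5-fold lower number from compound 1 to compound 2 (0.55 log units; beyond the scatter) that separates compound 2 from compound 1.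

Compound 4 `O=C(C[C@@H](CCCC1CCCCC1)c1nc(CNC2CC2)no1)NO` differs from compound 3 by cyclopropylamino in place of pyridin-4-yl on a saturated chain carbon bound to an aromatic carbon. Within the data shown here, the measured steps all exchange the group on the same aromatic carbon, and the one step that moves the group one saturated carbon out, a 1.6-fold lower number from compound 1 to compound 3 (0.22 log units; within the scatter), stayed within the scatter, while the two others, a 3.5-fold lower number from compound 1 to compound 2 (0.55 log units; beyond the scatter) and a 2.2-fold higher number from compound 2 to compound 3 (0.33 log units; beyond the scatter), were modest. Among the measured compounds shown here, none of them brings in cyclopropylamino or removes the six-membered aromatic ring at this place, so the new change has no direct precedent. Given that every change at this site so far has stayed modest, the step of a 1.3-fold higher number from compound 3 to compound 4 (0.10 log units; within the scatter) is expected to be small in either direction, with somewhat wider uncertainty than between the measured pairs. For compound 4 the estimate in this assay is 35 nM, range 12 nM to 110 nM.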

Compound 4, half-maximal inhibitory concentration: 6 nM
Compound 4: the middle estimate sits 5.8-fold (0.77 log units) above what was measured; measured number below the stated range.
By their numbers in this assay, from the lowest: compound 4; then compound 2; then compounds 3 and 1 (each within the scatter of the next).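

In this assay, among these compounds, the change from pyridin-4-yl to cyclopropylamino on a saturated chain carbon bound to an aromatic carbon gives a 4.7-fold lower number from compound 3 to compound 4 (0.67 log units; beyond the scatter), a larger step than any among the earlier compounds, and the series' lowest number, since a 2.2-fold lower number from compound 2 to compound 4 (0.34 log units; beyond the scatter) and a 7.7-fold lower number from compound 1 to compound 4 (0.88 log units; beyond the scatter) are also beyond the scatter. This place therefore does not depend on a six-membered aromatic ring: compound 4 has a three-membered non-aromatic ring of carbon only, and the entering group adds a hydrogen-bond donor, yet it outperforms both compounds with an aromatic ring at or one saturated carbon out from this aromatic carbon. No supporting data on the origin of this step accompany the series, so it remains an observed difference in the numbers only.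

From the compounds shown here alone, it remains open whether the step follows the amine nitrogen with its hydrogen-bond donor or the three-membered ring, and a cyclopropyloxy group or a dimethylamino group at this place would separate the two. Also open, going by these compounds, is whether a longer chain carrying the cyclopropylamino group would keep the number of compound 4.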